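The compounds below may be only part of what the source reports. "The series", "measured", "known", "first", "only" and "open" are said of these compounds alone.

In an ADME assay on HEK293 cells (Homo sapiens) for cytotoxicity, with a stated time of 72 h (a lower number here means that less compound is needed, a higher number that more compound is needed for the effect), compound 1 `Cc1cc(NC(=O)Nc2ccc(C(C)(C)C)cc2)c2ccccc2n1` gives > 25000 nM, which is a limit of the assay and not a number. Compound 2 `CCc1ccc(NC(=O)Nc2cc(C)nc3ccccc23)cc1` gives 16000 nM. Compound 3 `COC(=O)c1ccc(NC(=O)Nc2cc(C)nc3ccccc23)cc1` gives 15000 nM, which places it level with compound 2 within the scatter, as the step of a 1.1-fold lower number from compound 2 to compound 3 (0.03 log units; within the scatter) shows.

Compound 4 `Cc1cc(NC(=O)Nc2ccc(C(N)=O)cc2)c2ccccc2n1` keeps the shared core and has amino in place of methoxy on a carbonyl carbon, so that methoxycarbonyl becomes carbamoyl (amino in place of methoxy on a carbonyl carbon). Within the data shown here, no measured step makes this exact change. The nearest evidence comes from exchanges of the group on the aromatic carbon. The step between compound 2 and compound 3 has already been given. The other two exchanges are an at least 1.5-fold lower number from compound 1 to compound 2 (0.19 log units; that floor lies within the scatter) and an at least 1.6-fold lower number from compound 1 to compound 3 (0.22 log units; that floor lies within the scatter). None of these is shown to exceed the scatter, although two of them rest on a limit. On that basis, no step beyond the scatter is expected in this assay, and the expected change is a 1.2-fold higher number from compound 3 to compound 4 (0.08 log units; within the scatter). For compound 4, the estimated value is 18000 nM, with an expected range from 9000 nM to 36000 nM.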

Compound 4, half-maximal effective concentration: > 25000 nM
Compound 4 ended at the assay's limit; the forecaster's own chance of this, stated with the estimate: 40%; at least 1.3-fold (0.14 log units) between middle value and limit.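

In this assay compound 4 gives > 25000 nM, which is a limit of the assay and not a number. The earlier steps shown here only exchanged whole groups on the aromatic carbon, whereas this change on the carbonyl carbon gives an at least 1.6-fold higher number from compound 3 to compound 4 (0.22 log units; that floor lies within the scatter), and carbamoyl in place of ethyl on an aromatic carbon gives an at least 1.5-fold higher number from compound 2 to compound 4 (0.19 log units; that floor lies within the scatter). Neither floor is shown to exceed the scatter, so a real shift from keeping the carbonyl and exchanging methoxy for amino remains unproven, and the step from compound 1 to compound 4 cannot be read: the limit of > 25000 nM in this assay, at which 2 of the 4 values shown sit.

Going by these compounds, how large either readable step truly is stays open, since only its floor is known. On these data alone, it is also open whether a carboxylic acid or an amine on the same aromatic carbon would give a number or would also end at the limit.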